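Swapping an Aryl Group for an Ester Side Chain

The source may report more compounds than this note shows. Statements on the series, on what has been measured and on what is new or still open speak of the compounds shown alone.

Measured in an ADME assay on Huh-7 cells (Homo sapiens) for cytotoxicity; a higher number here means that more compound is tolerated, a lower number that less compound is tolerated:
compound 1, `Cc1ccccc1-c1nn(-c2ccccc2Cl)cc1CNCCN1CCN(C)CC1`, reported only as a limit: > 20000 nM
compound 2, `Cc1c(CNCCN2CCN(C)CC2)c(-c2ccccc2)nn1-c1ccc(F)cc1`, reported only as a limit: > 20000 nM
compound 3, `CN1CCN(CCNCc2cn(-c3ccc(F)cc3F)nc2C2CCCCC2)CC1`, reported only as a limit: > 20000 nM

Compound 1 therefore stands where every compound here stands, at the limit of > 20000 nM in this assay, at which 3 of the 3 values shown sit; none of these values is a number, so no order among the three can be read from them. Compound 4, `CCOC(=O)Cn1cc(CNCCN2CCN(C)CC2)c(-c2ccccc2C)n1`, differs from compound 1 in one place: (ethoxycarbonyl)methyl in place of 2-chlorophenyl on an aromatic nitrogen. Among the measured compounds shown here, no step between two measured compounds is available to guide the expectation. Since all three compounds share (the limit of > 20000 nM in this assay, at which 3 of the 3 values shown sit), the expectation for compound 4 is no step beyond the scatter, estimated as a step that the limit leaves unreadable from compound 1 to compound 4. Compound 4 is thus expected to give about 30000 nM in this assay, within a range from 15000 nM to 80000 nM, and most likely to be reported again only as a limit.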

Compound 4, half-maximal cytotoxic concentration: > 20000 nM
Compound 4: no number, only a limit (the forecaster's own chance of this, stated with the estimate: 80%); the middle value lies beyond the limit too.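

In this assay compound 4 is reported only as a limit (> 20000 nM). Among the compounds shown here, compound 1 is also only a limit, so no step from compound 1 to compound 4 can be read. The compounds shown leave open whether (ethoxycarbonyl)methyl in place of 2-chlorophenyl changes the tolerated concentration at all.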